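This account rests on a few compounds, and the source may have more. Where it says the series, first, only, none or still open, it means among the compounds named here.

In a functional assay on HeLa cells (Homo sapiens) for antiproliferative activity, read by MTT assay, with a stated time of 24 h (on this read-out higher numbers stand for weaker inhibition and lower numbers for stronger inhibition), compound 3 (`O=S(=O)(c1ccc(Cl)cc1)n1c(-c2cn(-c3ccccc3)nc2-c2ccc(C(F)(F)F)cc2)nc2ccccc21`) gives 3060 nM and lies within the scatter of compound 1 (`Cc1ccc(-c2nn(-c3ccccc3)cc2-c2nc3ccccc3n2S(=O)(=O)c2ccc(Br)cc2)cc1`) at 2340 nM, while compound 2 (`COc1ccc(S(=O)(=O)n2c(-c3cn(-c4ccccc4)nc3-c3ccc(C(F)(F)F)cc3)nc3ccccc32)cc1`) stands well apart at 250 nM on the low side. Compound 4 (`O=S(=O)(c1ccc(Br)cc1)n1c(-c2cn(-c3ccccc3)nc2-c2ccc(C(F)(F)F)cc2)nc2ccccc21`) has bromo in place of chloro on an aromatic carbon, para to a large group (bromo in place of chloro on an aromatic carbon). Among the measured compounds shown here, the only measured step at this place, a 12-fold higher number from compound 2 to compound 3 (1.09 log units; beyond the scatter) (large), swaps methoxy for chloro, not one halogen for another, and so guides little. Compound 1 already carries the (4-bromophenyl)sulfonyl group, and its 2340 nM stays within the scatter of compound 3. No step beyond the scatter is therefore expected in this assay here. The expected step reads (a 1.1-fold lower number from compound 3 to compound 4 (0.05 log units; within the scatter)). Compound 4 is estimated at 2700 nM (range 1300 nM to 5500 nM).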

Compound 4, half-maximal inhibitory concentration: 1860 nM
Beside the measured number, compound 4's estimate is 1.5-fold (0.16 log units) above it; low and high end bracket the measured number.
By their numbers in this assay, from the lowest: compound 2; then compounds 4, 1 and 3 (each within the scatter of the next).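

Swapping (4-chlorophenyl)sulfonyl for (4-bromophenyl)sulfonyl leaves the result in this assay unresolved, with a 1.6-fold lower number from compound 3 to compound 4 (0.22 log units; within the scatter). Methoxy stands apart from bromo as it does from chloro, with a 7.4-fold higher number from compound 2 to compound 4 (0.87 log units; beyond the scatter). With the (4-bromophenyl)sulfonyl group held constant, trifluoromethyl and methyl are not separated, with a 1.3-fold lower number from compound 1 to compound 4 (0.10 log units; within the scatter).

No measured evidence here bears on the cause of these steps. Open, as far as these compounds go, is whether an amino group, a hydroxyl or a longer ether such as ethoxy at this place would track with methoxy or with the halogens.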